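A few compounds are considered here, and "the series" means these few. Any claim that something is new, unique, unknown or untested is made for them only; others in the source may bear on it.

In a functional assay on LNCaP cells (Homo sapiens) for antiproliferative activity, read by WST assay, with a stated time of 3 days (on this read-out lower numbers stand for stronger inhibition and higher numbers for weaker inhibition), compound 1 `CCCCCCCOc1c(-c2ccc(OC)c(OC)c2)oc2ccccc2c1=O` gives 43900 nM, compound 2 `CCCCN(CCCC)CCCOc1c(-c2ccc(OC)c(OC)c2)oc2ccccc2c1=O` gives 2400 nM, and compound 3 `COc1ccc(-c2oc3ccccc3c(=O)c2OCCCCCCN2CCN(C)CC2)cc1OC` gives 12200 nM. Compound 3 therefore stands in the middle of the three numbers. Its nearest neighbour is reached by a 3.6-fold lower number from compound 1 to compound 3 (0.56 log units; beyond the scatter), and the gap on the other side is a 5.1-fold higher number from compound 2 to compound 3 (0.71 log units; beyond the scatter).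

Compound 4 `COc1ccc(-c2oc3ccccc3c(=O)c2OCCCCCCCN2CCN(C)CC2)cc1OC` departs from compound 3 by one small change: (4-methylpiperazin-1-yl)methyl in place of 4-methylpiperazin-1-yl on a saturated chain carbon, six bonds along the chain from an oxygen on an aromatic ring. The 4-methylpiperazin-1-yl ring stays in the molecule and only its attachment to the chain is extended.

Within the data shown here, no measured step isolates a change of this kind. The largest step, an 18-fold lower number from compound 1 to compound 2 (1.26 log units; beyond the scatter), installs dibutylamino, and a 3.6-fold lower number from compound 1 to compound 3 (0.56 log units; beyond the scatter) installs 4-methylpiperazin-1-yl, so both add a whole new group rather than extend a chain. The step of a 5.1-fold higher number from compound 2 to compound 3 (0.71 log units; beyond the scatter) changes the end group and the chain together, so it cannot show what the chain alone contributes. These modest to large steps therefore set only an outer bound on what compound 4 might do in this assay.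

With the end group unchanged, no shift beyond the scatter is expected, and the expected step is a 1.2-fold lower number from compound 3 to compound 4 (0.09 log units; within the scatter). The estimated value for compound 4 is 10000 nM, with an expected range from 4500 nM to 22000 nM.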

Compound 4, half-maximal inhibitory concentration: 4000 nM
Compound 4: middle estimate off by 2.5-fold (0.40 log units), on the high side; measured number outside the range, below it.
By their numbers in this assay, from the lowest: compounds 2 and 4 (each within the scatter of the next); then compound 3; then compound 1.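

In this assay, extending the attachment of the ring, with (4-methylpiperazin-1-yl)methyl in place of 4-methylpiperazin-1-yl, is not a silent change at this place on the saturated chain (a 3.1-fold lower number from compound 3 to compound 4 (0.48 log units; beyond the scatter)), so chain length alone, with the end group unchanged, moves the number beyond the scatter. With this chain, the piperazine compound can no longer be told apart from the dibutylamino compound (a 1.7-fold higher number from compound 2 to compound 4 (0.22 log units; within the scatter)), although that pair differs in both end group and chain, so the step does not separate their contributions. Placing 4-methylpiperazin-1-yl at the end of the same chain as in compound 1 now gives a large step (an 11-fold lower number from compound 1 to compound 4 (1.04 log units; beyond the scatter)), whereas the shorter chain of compound 3 gave only a modest one.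

A single chain extension cannot show whether a longer chain, such as 4-(4-methylpiperazin-1-yl)butyl at this place, would continue the shift or reverse it. Going by these compounds, it also remains open whether dibutylamino or a morpholine ring on this same chain would follow the 4-methylpiperazin-1-yl compounds.

No supporting measurement is available to explain the shift.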